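The compounds below may be only part of what the source reports. "The series", "measured", "known", "first", "only" and "open" are said of these compounds alone.

Compound 2 `COc1ccc(/C=C\C(=O)O)c(OCc2cn(-c3ccc(C#N)cc3)nn2)c1CC=C(C)C` gives 42200 nM in a functional assay on A549 cells (Homo sapiens) for cytotoxicity, read by MTT assay, with a stated time of 24 h; on this read-out higher numbers stand for weaker inhibition and lower numbers for stronger inhibition. Compound 1 `COc1cccc(-n2cc(COc3c(/C=C\C(=O)O)ccc(OC)c3CC=C(C)C)nn2)c1` gives 42700 nM in this assay, and the step of a 1.0-fold lower number from compound 1 to compound 2 (0.01 log units; within the scatter) shows that these two numbers cannot be told apart. Compound 3 `COc1ccc(/C=C\C(=O)O)c(OCc2cn(-c3nc4ccccc4s3)nn2)c1CC=C(C)C` has not yet been measured. It differs from compound 2 in a single place: 1,3-benzothiazol-2-yl in place of 4-cyanophenyl on an aromatic nitrogen. Within the data shown here, only one measured step touches the same place, the exchange of one aromatic group for another on an aromatic nitrogen, and that step, a 1.0-fold lower number from compound 1 to compound 2 (0.01 log units; within the scatter), brought no change beyond the scatter. Among the measured compounds shown here, the group that now enters did not appear in that step, so the guidance is weak, but the single precedent suggests that swapping the group at this position leaves the number roughly where it is. The expected step of a 1.1-fold lower number from compound 2 to compound 3 (0.02 log units; within the scatter) is accordingly small. The estimate for compound 3 is 40000 nM, with a likely range from 15000 nM to 110000 nM.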

Compound 3, half-maximal inhibitory concentration: 42100 nM
For compound 3 the middle estimate is 1.1-fold (0.02 log units) below the measured one; measured number inside the range.
By their numbers in this assay, from the lowest: compounds 3, 2 and 1 (each within the scatter of the next).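

In this assay, among these compounds, the step of a 1.0-fold lower number from compound 2 to compound 3 (0.00 log units; within the scatter) and the step of a 1.0-fold lower number from compound 1 to compound 3 (0.01 log units; within the scatter) extend the earlier picture: until now only two substituted phenyl groups had been compared on this aromatic nitrogen, whereas 1,3-benzothiazol-2-yl brings a five-membered aromatic ring with 2 hetero atoms along with its six-membered ring. Even so, compounds 1, 2 and 3 cannot be told apart, so for these three compounds the identity of the aromatic group makes no readable difference. No further measurement is available to explain this.

As far as these compounds go, what a non-aromatic group, such as a simple butyl chain or a morpholine, would do on this nitrogen stays open. So does the effect of a methyl ester in place of the carboxylic acid on the shared core.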